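The source may report more compounds than this note shows. Statements on the series, on what has been measured and on what is new or still open speak of the compounds shown alone.

Compound 1 `Cc1cc(NNC(=O)Nc2cc(Cl)nc(Cl)c2)ncc1N(C)C` gives > 23000 nM in a functional assay on CHO cells for agonist activity at sphingosine 1-phosphate receptor 2 (Homo sapiens), read by fluorescence and calcium flux, with a stated time of 3 min (a higher number here means a weaker inhibitor, a lower number a stronger inhibitor), a limit of the assay.
Compound 2 `Cc1cc(CO)nc(NNC(=O)Nc2cc(Cl)nc(Cl)c2)c1` gives > 23000 nM in this assay, also a limit.
Compound 3 `Cc1cc(NNC(=O)Nc2cc(Cl)nc(Cl)c2)ncc1-c1cnn(C)c1` gives > 23000 nM in this assay, again a limit.

Compound 2 thus stands at the limit, as do all values shown (the limit of > 23000 nM in this assay, at which 3 of the 3 values shown sit). Compound 4 `Cc1cc(NNC(=O)Nc2cc(Cl)nc(Cl)c2)nc(-c2cnn(C)c2)c1` differs from compound 2 by 1-methyl-1H-pyrazol-4-yl in place of hydroxymethyl on an aromatic carbon. For the measured compounds named here, the only measured step between compounds that differ in one place, a step that the two limits leave unreadable from compound 1 to compound 3, brings in the same group, yet its size cannot be read, as both ends sit at the limit. No direction can be drawn from the numbers for this assay, and another limit is the likeliest outcome. Compound 4 is therefore estimated at 30000 nM, with a range from 4000 nM to 200000 nM. The expected step that the limit leaves unreadable from compound 2 to compound 4 is estimated to remain unreadable against the limit.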

Compound 4, half-maximal inhibitory concentration: > 23000 nM
Compound 4: a limit, no number (the forecaster's own chance of this, stated with the estimate: 85%); the middle value is on the limit's open side.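

No new step can be read: compound 2 and compound 4 both stand at a limit. Which change to the shared core, if any, would give a readable number in this assay stays open: the limit of > 23000 nM in this assay, at which 4 of the 4 values shown sit.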